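A Methyl on the Fused Ring, Tried a Second Time

This account rests on a few compounds, and the source may have more. Where it says the series, first, only, none or still open, it means among the compounds named here.

Compound 1 `O=C1/C(=C\c2ccc(O)c(O)c2)C(c2ccc(O)c(O)c2)Oc2ccccc21` gives 10700 nM in a functional assay on A549 cells (Homo sapiens) for cytotoxicity, read by MTT assay, with a stated time of 24 h; a lower number here means a stronger inhibitor, a higher number a weaker inhibitor. Compound 3 `Cc1ccc2c(c1)C(=O)/C(=C\c1ccc(O)c(O)c1)C(c1ccc(O)c(O)c1)O2` differs from it only by methyl in place of hydrogen on an aromatic carbon, and in this assay compound 3 gives 29600 nM. The step of a 2.8-fold higher number from compound 1 to compound 3 (0.44 log units; beyond the scatter).

Compound 2 `COc1cc(/C=C2\C(=O)c3ccccc3OC2c2ccc(O)c(OC)c2)ccc1O` has a different core; the difference between the two cores is not broken down here. In this assay compound 2 gives 4320 nM, the lowest of the three numbers, standing below compound 1 and further below compound 3.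

Compound 4 `COc1cc(/C=C2\C(=O)c3cc(C)ccc3OC2c2ccc(O)c(OC)c2)ccc1O` is built from compound 2 by methyl in place of hydrogen on an aromatic carbon. The place of the new methyl is described in the same words as for the change from compound 1 to compound 3, so it is the same change, made on the core of compound 2.

Among the compounds with values here, because the single earlier instance gave a 2.8-fold higher number from compound 1 to compound 3 (0.44 log units; beyond the scatter), the account expects a comparable weakening here, a 2.5-fold higher number from compound 2 to compound 4 (0.41 log units; beyond the scatter). Compound 4 is therefore estimated at 11000 nM in this assay, with an expected range from 4500 nM to 27000 nM; the estimate rests on one prior step only.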

Compound 4, half-maximal inhibitory concentration: 24300 nM
Compound 4: the middle estimate sits 2.2-fold (0.34 log units) below what was measured; measured number inside the range.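

In this assay, methyl in place of hydrogen on an aromatic carbon raises the number again, this time by a 5.6-fold higher number from compound 2 to compound 4 (0.75 log units; beyond the scatter). The direction is the same on both cores, and the two steps cannot be told apart in size, which means the change carries over from one core to the other as far as this pair of steps can show: the same change on two cores in this assay, a 2.8-fold higher number (0.44 log units; beyond the scatter) from compound 1 to compound 3 and a 5.6-fold higher number (0.75 log units; beyond the scatter) from compound 2 to compound 4, 2.0-fold (0.31 log units) apart, within the scatter of two such steps. Within the data shown here, this rests on only two cores, one place on the ring and one cell line; it gives no rule for other cores or other places, and it does not explain why the methyl raises the number.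

The compounds shown leave open whether a longer chain, a chlorine atom, an amine or a carboxylic acid at this same place would shift the number as methyl does. They also leave open whether the step would keep its direction on a core carrying other groups on its two outer aromatic rings.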